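The source may hold more compounds than are shown below. What is called first, only, known or untested is meant among the compounds shown, and "the series" means these compounds.

Compound 1 `Cn1cncc1C(OCc1ccc(C#N)cc1/C=C/c1ccccn1)c1ccc(C#N)cc1` carries the only numerical result in this set: in a functional assay on NIH3T3 cells (Mus musculus) (a higher number here means that more compound is needed for the effect, a lower number that less compound is needed), compound 1 gives 23.1 nM. Compound 2 `Cn1cncc1C(OCc1ccc(C#N)cc1C#Cc1ccc(-c2ccccc2)cc1)c1ccc(C#N)cc1` has no number in this assay but only a limit, > 0.1 nM, which is the limit of > 0.1 nM in this assay, at which 1 of the 2 values shown sits. Compound 3 `Cn1cncc1C(OCc1ccc(C#N)cc1C#Cc1ccccc1)c1ccc(C#N)cc1` differs from compound 1 by 2-phenylethynyl in place of 2-(pyridin-2-yl)ethenyl on an aromatic carbon. No step between two measured compounds is shown for this change, so in this assay a shift not clearly beyond the usual scatter is expected, in either direction. For compound 3 the estimate is 20 nM, with a range from 5 nM to 80 nM, the expected step being a 1.2-fold lower number from compound 1 to compound 3 (0.06 log units; within the scatter).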

Compound 3, half-maximal effective concentration: 0.1 nM
For compound 3 the middle estimate is 200-fold (2.30 log units) above the measured one; measured number below the stated range.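

In this assay, 2-phenylethynyl in place of 2-(pyridin-2-yl)ethenyl on an aromatic carbon, ortho to a large group and meta to a cyano group, gives a large step: a 230-fold lower number from compound 1 to compound 3 (2.36 log units; beyond the scatter). Hydrogen in place of phenyl on an aromatic carbon gives a number no higher from compound 2 to compound 3 (the limit leaves the size open). Compound 2 carries only a limit, so the size of this step cannot be read: the limit of > 0.1 nM in this assay, at which 1 of the 3 values shown sits.

Ring and linking bond change together here, so the compounds shown do not assign the step to either one. A 2-phenylethenyl or 2-(pyridin-2-yl)ethynyl group at this position would separate the two.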